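Cytotoxicity of two benzimidazole amides and a planned urea

This account rests on a few compounds, and the source may have more. Where it says the series, first, only, none or still open, it means among the compounds named here.

Compound 2: `CN(C)c1cc2[nH]c(C3CCCCC3)nc2cc1NC(=O)c1ccco1`, > 100 ug/mL
Compound 1: `CCN(CC)c1cc2[nH]c(C3CCCCC3)nc2cc1NC(=O)NCc1ccccc1`, > 100 ug/mL

In an ADME assay on Vero cells (Chlorocebus sabaeus) for cytotoxicity, read by resazurin assay, with a stated time of 3 days (on this read-out lower numbers stand for stronger inhibition and higher numbers for weaker inhibition), compound 2 gives only a limit, > 100 ug/mL, and not a number. The other value shown is a limit as well: compound 1, `CCN(CC)c1cc2[nH]c(C3CCCCC3)nc2cc1NC(=O)NCc1ccccc1`, gives > 100 ug/mL in this assay. So compound 2 stands where every compound here stands, at the limit of > 100 ug/mL in this assay, at which 2 of the 2 values shown sit, with no measured number to set it apart.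

Compound 3, `CCCCNC(=O)Nc1cc2nc(C3CCCCC3)[nH]c2cc1N(C)C`, has not yet been measured in this assay. Its difference from compound 2 is butylamino in place of furan-2-yl on a carbonyl carbon. Compound 1 carries a urea of related type and also sits at the limit, so the account expects no step beyond the usual scatter in this assay, and in the same sense no clear direction. The step from compound 2 to compound 3 that this expectation means is a step that the limit leaves unreadable from compound 2 to compound 3. For compound 3 the estimate in this assay is 120 ug/mL, with a range from 55 ug/mL to 260 ug/mL, and most likely the assay will again report only a limit.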

Compound 3, half-maximal inhibitory concentration: > 100 ug/mL
Compound 3 gave a limit, no number (the forecaster's own chance of this, stated with the estimate: 80%); the middle value lies beyond the limit too.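

In this assay compound 3 gives > 100 ug/mL, which is a limit and not a number. No step can therefore be read between compound 2 and compound 3, since the values share one limit: the limit of > 100 ug/mL in this assay, at which 3 of the 3 values shown sit.

The compounds shown leave open what number any of them would give, and so how butylamino and furan-2-yl compare on a carbonyl carbon.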